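Swapping the carboxy for a cyano on compound 3

The source may hold more compounds than are shown below. What is called first, only, known or untested is meant among the compounds shown, and "the series" means these compounds.

Measured compounds:
- compound 1, `O=C(c1ccc(Cl)cc1)N1CCC(NS(=O)(=O)c2cc(S(=O)(=O)c3ccccc3)ccc2C(F)(F)F)CC1`, gives 300 nM
- compound 2, `O=C(c1ccc(Cl)nc1)N1CCC(NS(=O)(=O)c2cc(S(=O)(=O)c3ccccc3)ccc2C(F)(F)F)CC1`, gives 110 nM
- compound 3, `O=C(O)c1cccc(S(=O)(=O)N2CCC(NS(=O)(=O)c3cc(S(=O)(=O)c4ccccc4)ccc3C(F)(F)F)CC2)c1`, gives 20 nM

All three were tested in an assay on isolated protein for displacement of a labelled ligand from secreted frizzled-related protein 1 (Homo sapiens), read by fluorescence polarization, with a stated time of 30 min; on this read-out higher numbers stand for weaker inhibition and lower numbers for stronger inhibition. Compound 3 stands lowest of the three numbers: the step of a 15-fold lower number from compound 1 to compound 3 (1.18 log units; beyond the scatter) is large, and the step of a 5.5-fold lower number from compound 2 to compound 3 (0.74 log units; beyond the scatter) is modest, so compound 3 is the strongest of the measured set. Compound 4, `N#Cc1cccc(S(=O)(=O)N2CCC(NS(=O)(=O)c3cc(S(=O)(=O)c4ccccc4)ccc3C(F)(F)F)CC2)c1`, has not yet been measured. It differs from compound 3 in one place: cyano in place of carboxy on an aromatic carbon.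

For the measured compounds named here, no measured step changes only this carboxy. The two steps that brought the (3-carboxyphenyl)sulfonyl group in, from compound 1 and from compound 2, bear on it only loosely, since each of them also exchanged the carbonyl for a sulfonyl and changed the whole aromatic ring. What those steps show is that the compound carrying the carboxy group is the best of the three. Removing that group, and with it its hydrogen-bond donor, is therefore expected to cost some of the advantage in this assay, giving a higher number, though the size is uncertain. The expected step is a 4.0-fold higher number from compound 3 to compound 4 (0.60 log units; beyond the scatter). Compound 4 is estimated at 80 nM, with a range from 25 nM to 300 nM.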

Compound 4, half-maximal inhibitory concentration: 90 nM
For compound 4 the middle estimate is 1.1-fold (0.05 log units) below the measured one; the measured number falls inside the stated range.
By their numbers in this assay, from the lowest: compound 3; then compounds 4 and 2 (each within the scatter of the next); then compound 1.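

For the compounds shown here, for the first time, a single step isolates the group on this aromatic carbon: in this assay there is a 4.5-fold higher number from compound 3 to compound 4 (0.65 log units; beyond the scatter), so part of the advantage of compound 3 depends on the carboxy itself and not only on the sulfonyl link and ring that arrived with it. The replacement keeps some of the gain over the amide-type carbonyl compounds, with a 3.3-fold lower number from compound 1 to compound 4 (0.52 log units; beyond the scatter), but against the chloropyridine compound there is a 1.2-fold lower number from compound 2 to compound 4 (0.09 log units; within the scatter), so those two cannot be told apart and the (3-cyanophenyl)sulfonyl group offers no clear edge over the (6-chloropyridin-3-yl)carbonyl group. The carboxy has a hydrogen-bond donor and the cyano has none, while each has a hydrogen-bond acceptor, but no measurement here connects that count, or any other difference between the two groups, to the change in number.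

Still open, on these data alone, is whether a primary amide or a hydroxymethyl group on this same aromatic carbon would stay close to compound 3 or fall nearer to compound 4. A plain hydrogen there would also show how much the cyano contributes on its own.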